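This account rests on a few compounds, and the source may have more. Where it says the series, first, only, none or still open, it means among the compounds named here.

Compound 2 `COc1cccc(-n2c(=O)n(CCN3CCN(c4ccccc4)CC3)c3ccccc32)c1` gives 864 nM in an assay on HEK293 cells for displacement of a labelled ligand from 5-hydroxytryptamine receptor 7 (Homo sapiens) (a lower number here means a stronger inhibitor, a higher number a weaker inhibitor), and so carries the lowest of the three numbers recorded, but this standing is slight: compound 1 `O=c1n(CCN2CCN(c3ccccc3)CC2)c2ccccc2n1-c1ccccc1` gives 1230 nM and compound 3 `O=c1[nH]c2ccccc2n1CCN1CCN(c2ccccc2)CC1` gives 1030 nM, and the steps of a 1.4-fold lower number from compound 1 to compound 2 (0.15 log units; within the scatter) and a 1.2-fold higher number from compound 2 to compound 3 (0.08 log units; within the scatter) both stay within the scatter. Compound 4 `COc1cccc(-n2c(=O)n(CCN3CCN(c4ccccc4C)CC3)c3ccccc32)c1` differs from compound 2 in one place: methyl in place of hydrogen on an aromatic carbon. Going by the values given here, none of the measured steps touches this part of the molecule; each of them alters the group on the aromatic nitrogen of the shared core, and each remained within the scatter. No basis therefore exists for expecting a shift beyond the scatter, and the expected step is a 1.1-fold lower number from compound 2 to compound 4 (0.03 log units; within the scatter). Compound 4 is estimated at 800 nM, between 300 nM and 2500 nM.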

Compound 4, inhibition constant: 2500 nM
Beside the measured number, compound 4's estimate is 3.1-fold (0.49 log units) below it; the measured number falls inside the stated range.
By their numbers in this assay, from the lowest: compounds 2, 3 and 1 (each within the scatter of the next); then compound 4.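

In this assay, the change from phenyl to 2-methylphenyl gives a 2.9-fold higher number from compound 2 to compound 4 (0.46 log units; beyond the scatter), the only step shown that goes beyond the scatter, and a modest one. Every earlier step altered the group on the aromatic nitrogen of the shared core, so this position is the first shown to respond, and a single added methyl is enough. Nothing shown accounts for this shift. As far as these compounds go, whether a chlorine atom or an ethyl group at this place would give a similar step remains open. So does whether methyl would do the same on compound 1 or compound 3.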